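A few compounds are considered here, and "the series" means these few. Any claim that something is new, unique, unknown or untested is made for them only; others in the source may bear on it.

Working notes on the series.

Compound 1 `NC(=O)c1c(NC(=O)c2ccccc2Cl)sc2c1CCN(Cc1ccccc1Cl)C2` is the lower of the two numbers available in a functional assay on HL-60 cells (Homo sapiens) for antiproliferative activity, with a stated time of 24 h; on this read-out lower numbers stand for stronger inhibition and higher numbers for weaker inhibition: compound 1 gives 2900 nM. Compound 2 `NC(=O)c1c(NC(=O)c2ccccc2F)sc2c1CCN(Cc1ccc(Cl)cc1Cl)C2` gives 13100 nM in this assay, and the gap between the two lies beyond the scatter; the two compounds differ in more than one place, so nothing is read into that gap beyond the values themselves.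

Compound 3 `NC(=O)c1c(NC(=O)c2ccccc2Cl)sc2c1CCN(C(=O)Nc1ccccc1Cl)C2` is not yet measured. It differs from compound 1 in a single place: (2-chlorophenyl)carbamoyl in place of 2-chlorobenzyl on an amine nitrogen in a ring. Among the compounds with values here, no pair of measured compounds shows this kind of replacement, so there is no measured step to lean on.

The expectation for this assay is a moderate step to a higher number, at the edge of the scatter: the estimated step is a 1.7-fold higher number from compound 1 to compound 3 (0.24 log units; within the scatter). For compound 3 the estimate is 5000 nM, with a range from 1500 nM to 17000 nM.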

Compound 3, half-maximal inhibitory concentration: 12500 nM
Compound 3: middle estimate off by 2.5-fold (0.40 log units), on the low side, and the stated range covers the measured number.
By their numbers in this assay, from the lowest: compound 1; then compounds 3 and 2 (each within the scatter of the next).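

Within the data shown here, on the amine nitrogen in a ring, (2-chlorophenyl)carbamoyl in place of 2-chlorobenzyl gives a 4.3-fold higher number from compound 1 to compound 3 (0.63 log units; beyond the scatter) in this assay, the first single-place comparison and a sign that this position is not indifferent to the group it carries. The chlorinated aromatic ring is present in both groups, so the step goes with the change in how that ring is linked to the ring nitrogen, not with the loss of the ring itself. No measurement on hand explains the step, and the carbonyl and the amide hydrogen of the entering group cannot be told apart as contributors.

Still open, from the compounds shown here alone, is whether a 2-chlorophenylacetyl group or a longer chain such as 2-chlorophenethyl on the same nitrogen would read closer to compound 1 or to compound 3.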